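The compounds below may be only part of what the source reports. "The series", "measured", "known", "first", "only" and "open" are said of these compounds alone.

Working notes on the series. In a functional assay on MDA-MB-468 cells (Homo sapiens) for inhibition, read by MTT assay (a lower number here means a stronger inhibitor of growth, a higher number a weaker inhibitor of growth), compound 1 `CC1=C(/C=C/C(C)=C/C=C/C(C)=C\C(=O)Nc2cccc(F)c2)C(C)(C)CCC1n1ccnc1` gives 6760 nM while compound 2 `CC1=C(/C=C/C(C)=C/C=C/C(C)=C\C(=O)Nc2ccc(F)cc2)C(C)(C)CCC1n1ccnc1` gives 4570 nM and stands level with it within the scatter. Among the compounds with values here, the one measured step of a 1.5-fold lower number from compound 1 to compound 2 (0.17 log units; within the scatter) exchanges 3-fluorophenyl for 4-fluorophenyl on an amide-type nitrogen. Compound 3 `CC1=C(/C=C/C(C)=C/C=C/C(C)=C\C(=O)NCc2ccc(O)cc2)C(C)(C)CCC1n1ccnc1` carries 4-hydroxybenzyl in place of 4-fluorophenyl on an amide-type nitrogen. Within the data shown here, no measured compound carries 4-hydroxybenzyl, so that step is only a weak guide to this larger change. A modest move towards a lower number is expected, and the estimated step is small against the wide range (a 1.8-fold lower number from compound 2 to compound 3 (0.26 log units; within the scatter)). Compound 3 is estimated at 2500 nM with an expected range of 600 nM to 8000 nM in this series.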

Compound 3, concentration for 50% growth inhibition: 2700 nM
The estimate for compound 3 lay 1.1-fold (0.03 log units) below the measured number; the range from low to high includes it.
By their numbers in this assay, from the lowest: compounds 3, 2 and 1 (each within the scatter of the next, the first and the last beyond it).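

In this assay, 4-hydroxybenzyl on the amide-type nitrogen, which brings in a hydrogen-bond donor and acceptor absent from 4-fluorophenyl, gives a 1.7-fold lower number from compound 2 to compound 3 (0.23 log units; within the scatter), so this change does not separate the two compounds. Set against 3-fluorophenyl, the same group gives a 2.5-fold lower number from compound 1 to compound 3 (0.40 log units; beyond the scatter), the first modest difference in the series to pass the scatter. No evidence on hand accounts for these numbers. Going by these compounds, it stays open whether the hydroxyl or the benzyl link carries that difference, and how an unsubstituted benzyl or a 4-methoxybenzyl group would read at this nitrogen.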